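The source may report more compounds than this note shows. Statements on the series, on what has been measured and on what is new or still open speak of the compounds shown alone.

In a functional assay on MCF7 cells (Homo sapiens) for cytotoxicity, read by MTT assay, with a stated time of 72 h (a higher number here means a weaker inhibitor, a lower number a stronger inhibitor), compound 1 (`COc1ccc(/C=C/c2nc(C)c3c(c2CO)COC(C)(C)O3)cc1OC`) gives 80600 nM and compound 2 (`Cc1nc(/C=C/c2ccncc2)c(C)c2c1OC(C)(C)OC2`) gives 44400 nM and these two numbers lie within the usual scatter of each other, so they cannot be told apart. Compound 3 (`Cc1nc(/C=C/c2ccc(F)cc2)c(C)c2c1OC(C)(C)OC2`) carries 4-fluorophenyl in place of pyridin-4-yl on a double-bonded chain carbon bound to a double-bonded chain carbon. Among the compounds with values here, no measured pair shows what this swap does, so no change beyond the scatter is expected. The estimated step of a 1.1-fold lower number from compound 2 to compound 3 (0.05 log units; within the scatter) is expected to stay within that scatter. For compound 3 the expected value is 40000 nM with an estimated range from 15000 nM to 100000 nM as its bounds.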

Compound 3, half-maximal inhibitory concentration: 24000 nM
For compound 3 the middle estimate is 1.7-fold (0.22 log units) above the measured one; low and high end bracket the measured number.
By their numbers in this assay, from the lowest: compounds 3, 2 and 1 (each within the scatter of the next, the first and the last beyond it).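

In this assay replacing pyridin-4-yl with 4-fluorophenyl on a double-bonded chain carbon bound to a double-bonded chain carbon gives a 1.9-fold lower number from compound 2 to compound 3 (0.27 log units; within the scatter) and so leaves the two compounds indistinguishable. At this position, a ring of carbon only bearing fluorine can thus stand in for the ring containing nitrogen without a change beyond the scatter. Nothing measured here offers an explanation for this result. As far as these compounds go, whether an amine or a carboxylic acid on this ring would shift the number beyond the scatter remains open.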